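This account rests on a few compounds, and the source may have more. Where it says the series, first, only, none or still open, it means among the compounds named here.

Measured so far in a functional assay on CHO cells for agonist activity at sphingosine 1-phosphate receptor 5 (Homo sapiens), read by GTPgammaS binding; on this read-out higher numbers stand for an effect only at larger amounts of compound and lower numbers for an effect already at smaller amounts:
compound 1, `COc1cc(-c2nc(-c3ccc(CCC(=O)O)cc3C)no2)ccc1OC(C)C` — 270 nM
compound 2, `Cc1cc(CCC(=O)O)ccc1-c1noc(-c2ccc(CC(C)C)nc2)n1` — > 1000 nM, a limit of the assay rather than a number

Compound 2 therefore stands only at the limit of > 1000 nM in this assay, at which 1 of the 2 values shown sits, and no number places it against compound 1. Compound 1 carries its isopropoxy on a benzene ring beside a methoxy group and gives 270 nM in this assay.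

The next compound, compound 3 with structure `Cc1cc(CCC(=O)O)ccc1-c1noc(-c2ccc(OC(C)C)nc2)n1`, is derived from compound 2 by one exchange: isopropoxy in place of isobutyl on an aromatic carbon, the carbon sitting next to the ring nitrogen and para to a large group. No measured pair shows this exact exchange, so the size of the step cannot be read from the data shown.

Compound 3 is expected to reach the assay window, with an estimated value of 600 nM (range 200 nM to 2000 nM), which would mean an estimated step of an at least 1.6-fold lower number from compound 2 to compound 3 (0.22 log units; that floor lies within the scatter).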

Compound 3, half-maximal effective concentration: > 10000 nM
Compound 3: no number, only a limit (the forecaster's own chance of this, stated with the estimate: 35%); at least 16-fold (1.22 log units) between middle value and limit.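

In this assay compound 3 gives > 10000 nM, a limit of the assay and not a number. Among these compounds, compound 2 also stands only at a limit, so no step between compound 2 and compound 3 can be read. The compounds shown leave open both the size and the direction of the change from isobutyl to isopropoxy.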